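From a furan amide to a pyrimidine amide

This account rests on a few compounds, and the source may have more. Where it says the series, first, only, none or still open, it means among the compounds named here.

Three compounds share one core and differ only in the ring attached to the carbonyl of the amide. Compound 1, `COc1cccc(C(=O)Nc2ccc(Cl)cc2CN2C(=O)c3ccccc3C2=O)c1`, carries a 3-methoxyphenyl there, compound 2, `O=C(Nc1ccc(Cl)cc1CN1C(=O)c2ccccc2C1=O)c1ccccc1[N+](=O)[O-]`, a 2-nitrophenyl, and compound 3, `O=C(Nc1ccc(Cl)cc1CN1C(=O)c2ccccc2C1=O)c1ccco1`, a furan-2-yl. In an assay on CHO cells for positive allosteric modulation of metabotropic glutamate receptor 5 (Rattus norvegicus), read by FLIPR (on this read-out lower numbers stand for an effect already at smaller amounts and higher numbers for an effect only at larger amounts of compound), compound 1 gives only a limit, < 1000 nM. In this assay compound 2 likewise gives a limit, < 1000 nM. Compound 3 also stands at a limit, < 1000 nM. Because all three sit at the limit of < 1000 nM in this assay, at which 3 of the 3 values shown sit, the steps a step that the two limits leave unreadable from compound 1 to compound 2, a step that the two limits leave unreadable from compound 1 to compound 3 and a step that the two limits leave unreadable from compound 2 to compound 3 cannot be read in size or direction. Compound 4, `O=C(Nc1ccc(Cl)cc1CN1C(=O)c2ccccc2C1=O)c1ncccn1`, brings the next change: pyrimidin-2-yl in place of furan-2-yl on a carbonyl carbon. For the measured compounds named here, no measured step tells how large this change might be; the only guidance is that compounds 1, 2 and 3 all stand at the same limit in this assay. The estimate for compound 4 is therefore 400 nM, with a range from 60 nM to 2500 nM. The expected step that this estimate implies is a step that the limit leaves unreadable from compound 3 to compound 4.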

Compound 4, half-maximal effective concentration: < 1000 nM
Compound 4 ended at the assay's limit (the forecaster's own chance of this, stated with the estimate: 65%); the middle value lies beyond the limit too.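

Compound 4 stands with compounds 1, 2 and 3 in this assay, and the steps from each of them to compound 4 cannot be read, because all four sit at one limit: the limit of < 1000 nM in this assay, at which 4 of the 4 values shown sit.

As far as these compounds go, whether the ring on the carbonyl carbon changes the effect at all, and by how much, stays open.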